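A few compounds are considered here, and "the series" means these few. Any claim that something is new, unique, unknown or untested is made for them only; others in the source may bear on it.

Compound 1 `CCNc1cc(Nc2cccc(Cl)c2)ncn1`, compound 2 `CCOC(=O)CCCC(=O)Nc1cc(Nc2cccc(Cl)c2)ncn1` and compound 3 `O=C(O)CCCC(=O)Nc1cc(Nc2cccc(Br)c2)ncn1` share one core and were each examined in an assay for inhibition of Receptor tyrosine-protein kinase erbB-3 variant L858R (Homo sapiens), read by mobility shift assay, with a stated time of 10 min; a higher number here means a weaker inhibitor, a lower number a stronger inhibitor. In this assay compound 1 gives only a limit, > 10000 nM. In this assay compound 2 likewise gives only a limit, > 10000 nM. Compound 3 also reaches only a limit, > 10000 nM, so it stands at the limit and not at a number, and no measured step between any two of these compounds can be stated. Compound 4 `CCOC(=O)CCC(=O)Nc1cc(Nc2cccc(Br)c2)ncn1` has not yet been measured and differs from compound 3 by ethoxycarbonyl in place of carboxymethyl on a saturated chain carbon, two bonds along the chain from a carbonyl carbon. Since every value shown sits at the limit of > 10000 nM in this assay, at which 3 of the 3 values shown sit, the step from compound 3 to compound 4 is expected to be none beyond the scatter, an expected change of a step that the limit leaves unreadable from compound 3 to compound 4. Compound 4 is therefore estimated at 15000 nM, within 5000 nM to 50000 nM, most likely again as a limit.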

Compound 4, half-maximal inhibitory concentration: 1350 nM
Estimate against measurement, compound 4: 11-fold (1.05 log units) above; the whole stated range lies above it.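

In this assay the swap of carboxymethyl for ethoxycarbonyl gives an at least 7.4-fold lower number from compound 3 to compound 4 (0.86 log units; beyond the scatter) and so shows that the value responds to a change at this saturated chain carbon. Compound 4 is the only compound shown that leaves the limit: the limit of > 10000 nM in this assay, at which 3 of the 4 values shown sit. Read one bond further out, the change is 3-carboxypropyl to 2-(ethoxycarbonyl)ethyl, so the end group and the chain differ together. The compounds shown do not separate these two differences. On these data alone, how a 2-carboxyethyl group or a primary amide at the chain end would read on the core of compound 4 remains open.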